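The source may hold more compounds than are shown below. What is called first, only, known or untested is meant among the compounds shown, and "the series" means these compounds.

Of the compounds shown here, three built on one shared core have been measured in a functional assay for inhibition, tested at 40 ug/mL; a higher number here means a stronger effect of the compound at the concentration tested, a lower number a weaker effect. Compound 1 `Cc1cc(O)c(C(C)C)cc1-c1cc(-c2cccs2)c(C#N)c(=O)[nH]1` gives 41%. Compound 2 `COc1ccc(-c2cc(-c3cc(C(C)C)c(O)cc3C)[nH]c(=O)c2C#N)c(OC)c1` gives 37.5%. Compound 3 `Cc1cc(O)c(C(C)C)cc1-c1cc(-c2ccco2)c(C#N)c(=O)[nH]1` gives 42.5%, the highest of the three numbers, though both others sit within the scatter of it: a number 1.5 percentage points higher from compound 1 to compound 3 (within the scatter) and a number 5 percentage points higher from compound 2 to compound 3 (within the scatter). Compound 4 `Cc1cc(O)c(C(C)C)cc1-c1cc(-c2ccccc2Cl)c(C#N)c(=O)[nH]1` has not yet been measured; it differs from compound 3 in one place, (2-chlorophenyl in place of furan-2-yl on an aromatic carbon). The earlier exchanges at this same position, among thiophen-2-yl, furan-2-yl and 2,4-dimethoxyphenyl, all stayed within the scatter, so no step beyond the scatter is expected in this assay here either. Compound 4 is therefore estimated at 41%, between 31% and 51%. The expected step is a number 1.5 percentage points lower from compound 3 to compound 4 (within the scatter).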

Compound 4, a percentage reported as inhibition, at one concentration (the size of the read-out at that concentration, not a potency): 20%
Beside the measured number, compound 4's estimate is 21 percentage points above it, outside the stated range (below it).
By their numbers in this assay, from the lowest: compound 4; then compounds 2, 1 and 3 (each within the scatter of the next).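

In this assay this position does respond to the group placed on it: 2-chlorophenyl brings a number 22.5 percentage points lower from compound 3 to compound 4 (beyond the scatter), along with a number 17.5 percentage points lower from compound 2 to compound 4 (beyond the scatter) and a number 21 percentage points lower from compound 1 to compound 4 (beyond the scatter). A six-membered aromatic ring alone does not go with the loss, since compound 2 carries 2,4-dimethoxyphenyl there and stays within the scatter of compound 1 and compound 3. Nothing available here explains the result.

On these data alone, it remains open whether the chlorine matters or the phenyl ring bearing it. A plain phenyl group, or a methyl group or an amine in place of the chlorine, would separate these.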